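Swapping Trifluoromethyl for Trifluoromethoxy on the Aryl Ring

The source may report more compounds than this note shows. Statements on the series, on what has been measured and on what is new or still open speak of the compounds shown alone.

For the measured compounds named here, compound 2 `C[C@]1(O)C[C@@](c2cccc(C(F)(F)F)c2)([C@H](O)c2ccccn2)C1` gives 300 nM in an assay on HEK293 cells for antagonist activity at transient receptor potential cation channel subfamily V member 3 (Homo sapiens), read by FLIPR and calcium flux (on this read-out higher numbers stand for weaker inhibition and lower numbers for stronger inhibition), the higher of the two numbers measured so far. Compound 1 `O[C@H](c1ccccn1)[C@]1(c2cccc(OC(F)(F)F)c2)C[C@@H](O)C1`, which carries a trifluoromethoxy group and lacks the methyl on the shared core, gives 80 nM in this assay. Compound 3 `C[C@]1(O)C[C@@](c2cccc(OC(F)(F)F)c2)([C@H](O)c2ccccn2)C1` keeps the core of compound 2 with one change: trifluoromethoxy in place of trifluoromethyl on an aromatic carbon. Going by the values given here, no measured pair isolates this change, so the expectation rests on the two values alone: a modest downward step a 2.0-fold lower number from compound 2 to compound 3 (0.30 log units; within the scatter) is expected, not far beyond the scatter. Compound 3 is therefore estimated at 150 nM, within 50 nM to 450 nM.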

Compound 3, antagonist equilibrium constant: 280 nM
Estimate against measurement, compound 3: 1.9-fold (0.27 log units) below; the range from low to high includes it.
By their numbers in this assay, from the lowest: compound 1; then compounds 3 and 2 (each within the scatter of the next).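

On the aromatic carbon, trifluoromethoxy in place of trifluoromethyl gives a 1.1-fold lower number from compound 2 to compound 3 (0.03 log units; within the scatter) in this assay, so the two groups cannot be told apart on the methyl-bearing core. With trifluoromethoxy held fixed, methyl in place of hydrogen on a saturated ring carbon gives a 3.5-fold higher number from compound 1 to compound 3 (0.54 log units; beyond the scatter), a step that shows inhibition weakening with the added methyl. No supporting evidence is available to explain either result. Still open, as far as these compounds go, is whether trifluoromethyl and trifluoromethoxy also match on the core without the methyl. From the compounds shown here alone, it is also open how an ethyl group or a fluorine at the methyl's place would read.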